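Single methoxy removal in the sulfonamide series

This account rests on a few compounds, and the source may have more. Where it says the series, first, only, none or still open, it means among the compounds named here.

Values so far in a functional assay on CHO-TAX 5-6 cells (Cricetulus griseus) for antiproliferative activity, read by sulforhodamine B assay, with a stated time of 48 h; on this read-out higher numbers stand for weaker inhibition and lower numbers for stronger inhibition
Compound 1 `CCc1cccc(NS(=O)(=O)c2ccc(N3CCNC3=O)cc2)c1` gives 140 nM
Compound 2 `COc1cc(NS(=O)(=O)c2ccc(N3CCNC3=O)cc2)cc(OC)c1` gives 220 nM

Compound 2 at 220 nM lies within the usual scatter of compound 1 at 140 nM, so these two values do not separate the compounds. Compound 3 `COc1cccc(NS(=O)(=O)c2ccc(N3CCNC3=O)cc2)c1` has hydrogen in place of methoxy on an aromatic carbon of compound 2, at a place meta to a large group and meta to a methoxy group (hydrogen in place of methoxy on an aromatic carbon). Going by the values given here, no pair measured so far differs in one place, so the data show no direct precedent for this change in this assay. With only the closeness of those two values to go on, a change no larger than the scatter is expected, with no firm direction. The expected step is a 1.2-fold lower number from compound 2 to compound 3 (0.09 log units; within the scatter), which stays within that scatter. For compound 3 the estimated value is 180 nM, with an expected range of 70 nM to 450 nM.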

Compound 3, half-maximal inhibitory concentration: 200 nM
Estimate against measurement, compound 3: 1.1-fold (0.05 log units) below; the range from low to high includes it.
By their numbers in this assay, from the lowest: compounds 1, 3 and 2 (each within the scatter of the next).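

In this assay, going by these compounds alone, hydrogen in place of methoxy on an aromatic carbon gives a 1.1-fold lower number from compound 2 to compound 3 (0.04 log units; within the scatter), the first direct pair for this change, so at this place, meta to a large group and meta to a methoxy group, the two groups are not told apart on this read-out. Methoxy in place of ethyl on an aromatic carbon gives a 1.4-fold higher number from compound 1 to compound 3 (0.15 log units; within the scatter), so these two groups are not told apart either, and all the single-place steps in hand remain inside the scatter. No independent measurement bears on this result.

Going by these compounds, whether an amine or a carboxylic acid on this aromatic carbon, or a longer chain in place of the ethyl of compound 1, would give a step beyond the scatter stays open. On these data alone, the effect of hydrogen in place of the remaining methoxy of compound 3 is also open.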